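Removing the Methyl from the Most Active Succinimide Amide

The compounds below may be only part of what the source reports. "The series", "measured", "known", "first", "only" and "open" are said of these compounds alone.

Measured compounds:
compound 1 `CCC(C(=O)N1CCN(c2cccc(C(F)(F)F)c2)CC1)N1C(=O)CCC1=O`: 75%
compound 2 `CCC(C(=O)N1CCN(c2cccc(C)c2)CC1)N1C(=O)CCC1=O`: 100%

Both compounds were tested in a functional assay on the whole organism (strain Swiss) with Mus musculus as the target, in the maximal electroshock model, with a stated time of 0.25 h, at a dose of 300 mg/kg by the intraperitoneal route; a higher number here means a stronger effect of the compound at the dose given, a lower number a weaker effect. Compound 2 stands highest of the two numbers, with compound 1 as its nearest neighbour; the step of a number 25 percentage points higher from compound 1 to compound 2 (beyond the scatter) lies beyond the scatter and came from a single change on the aromatic ring, methyl in place of trifluoromethyl on an aromatic carbon.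

Compound 3 `CCC(C(=O)N1CCN(c2ccccc2)CC1)N1C(=O)CCC1=O` has not yet been measured. It differs from compound 2 at the same aromatic carbon: hydrogen in place of methyl on an aromatic carbon. Among the measured compounds shown here, only one measured step touches this position, the one from compound 1 to compound 2, and it shows that the group on this carbon can shift the read-out in this assay by a modest amount. For the measured compounds named here, no measured pair shows what happens when the group is taken away altogether.

Because of that single step a number 25 percentage points higher from compound 1 to compound 2 (beyond the scatter), a change at this carbon is expected to matter, but in which direction is not settled by the data. Compound 3 is therefore expected to stay near compound 2, with the step of a number 10 percentage points lower from compound 2 to compound 3 (within the scatter) estimated as small. The estimate for compound 3 is 90%, within 70% to 100%.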

Compound 3, a percentage reported as activity, at one dose (the size of the read-out at that dose, not a potency): 75%
Compound 3: the middle estimate sits 15 percentage points above what was measured, and the stated range covers the measured number.
By their numbers in this assay, from the lowest: compounds 1 and 3 (each within the scatter of the next); then compound 2.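

In this assay, taking the methyl group off the ring gives a number 25 percentage points lower from compound 2 to compound 3 (beyond the scatter), so the higher read-out of compound 2 depends on having methyl on this carbon, not merely on the absence of trifluoromethyl. Replacing trifluoromethyl with plain hydrogen gives no change at the digits printed from compound 1 to compound 3 (within the scatter), which means that, at this dose, trifluoromethyl offers no measurable advantage over an unsubstituted phenyl ring, and of the three groups only methyl stands apart. Nothing available here explains why methyl behaves differently from the other two groups.

Going by these compounds, it remains open whether an ethyl chain, a methoxy group or a chlorine atom on this same carbon would match methyl or fall back to the level shared by the other two compounds. Also open, on these data alone, is how compound 1, compound 2 and compound 3 would compare at a lower dose, given that this read-out reflects the size of the effect at one dose and not potency.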